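This account rests on a few compounds, and the source may have more. Where it says the series, first, only, none or still open, it means among the compounds named here.

Three compounds that share one core have been examined in an ADME assay on HEL cells (Homo sapiens) for cytotoxicity, with a stated time of 3 days; a higher number here means that more compound is tolerated, a lower number that less compound is tolerated. Compound 1 `Cc1cn([C@@H]2O[C@H](CO[Si](C)(C)C(C)(C)C)[C@@]3(OS(=O)(=O)C=C3NC(=O)NC(=O)c3ccccc3)[C@H]2O[Si](C)(C)C(C)(C)C)c(=O)n(C)c1=O` carries a benzoyl group on an amide-type nitrogen; in this assay compound 1 gives only a limit, > 200000 nM. Compound 2 `Cc1cn([C@@H]2O[C@H](CO[Si](C)(C)C(C)(C)C)[C@@]3(OS(=O)(=O)C=C3NC(=O)Nc3ccccc3)[C@H]2O[Si](C)(C)C(C)(C)C)c(=O)n(C)c1=O` has a phenyl at that nitrogen, and in this assay compound 2 gives 1300 nM. Compound 3 `Cc1cn([C@@H]2O[C@H](CO[Si](C)(C)C(C)(C)C)[C@@]3(OS(=O)(=O)C=C3NC(=O)NCc3ccccc3)[C@H]2O[Si](C)(C)C(C)(C)C)c(=O)n(C)c1=O` has a benzyl there, and in this assay compound 3 gives 4100 nM, the higher of the two numbers, with compound 2 its nearest neighbour (a 3.2-fold higher number from compound 2 to compound 3 (0.50 log units; beyond the scatter)). Compound 1 stands apart at the limit of > 200000 nM in this assay, at which 1 of the 3 values shown sits.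

Compound 4 `Cc1cn([C@@H]2O[C@H](CO[Si](C)(C)C(C)(C)C)[C@@]3(OS(=O)(=O)C=C3NC(N)=O)[C@H]2O[Si](C)(C)C(C)(C)C)c(=O)n(C)c1=O` alters the same nitrogen once more: hydrogen in place of benzyl on an amide-type nitrogen. The measured steps at this nitrogen were an at least 150-fold lower number from compound 1 to compound 2 (2.18 log units; beyond the scatter), an at least 48-fold lower number from compound 1 to compound 3 (1.68 log units; beyond the scatter) and a 3.2-fold higher number from compound 2 to compound 3 (0.50 log units; beyond the scatter), so every change here has moved the number beyond the scatter, and the largest moves came when the group on the nitrogen was changed in kind rather than in length. The step from compound 3 to compound 4 is therefore expected to be a sizeable rise, a 7.3-fold higher number from compound 3 to compound 4 (0.86 log units; beyond the scatter). Compound 4 is estimated at 30000 nM, within a range from 5000 nM to 200000 nM.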

Compound 4, half-maximal cytotoxic concentration: 11000 nM
Compound 4: middle estimate off by 2.7-fold (0.44 log units), on the high side; the range from low to high includes it.
By their numbers in this assay, from the lowest: compound 2; then compound 3; then compound 4. At a limit, above all of these: compound 1.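

Hydrogen on this amide-type nitrogen, the bare ureido group, gives a higher number than either benzyl or phenyl, with a 2.7-fold higher number from compound 3 to compound 4 (0.43 log units; beyond the scatter) and an 8.5-fold higher number from compound 2 to compound 4 (0.93 log units; beyond the scatter), so in this assay the lowest numbers so far go with a group that carries a six-membered aromatic ring. Benzoyl goes against that reading: it also carries such a ring, yet the step with hydrogen runs the other way, an at least 18-fold lower number from compound 1 to compound 4 (1.25 log units; beyond the scatter). For compound 1 the value remains a limit and not a number: the limit of > 200000 nM in this assay, at which 1 of the 4 values shown sits.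

The compounds shown leave open whether methyl or a longer alkyl chain on this nitrogen would sit with hydrogen or with benzyl, and whether acetyl would behave like benzoyl. They also leave open what an amine or a carboxylic acid on the ring of compound 2 would do to its number.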